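Methoxy in Place of Methyl on the Sulfanyl Arm

A few compounds are considered here, and "the series" means these few. Any claim that something is new, unique, unknown or untested is made for them only; others in the source may bear on it.

Compound 1 `Cc1ccc(CSc2nc3nc(C)cc(Nc4cc(-c5ccccc5)[nH]n4)n3n2)cc1` is the starting point of this account. Going by the values given here, in an ADME assay on GES1 cells (Homo sapiens) for inhibition, read by MTT assay, with a stated time of 72 h (on this read-out higher numbers stand for weaker inhibition and lower numbers for stronger inhibition), compound 1 gives 36200 nM, the only outright number among the three values shown for this assay. Compound 2 `Cc1cc(Nc2cc(-c3ccccc3)[nH]n2)n2nc(SCC3CC3)nc2n1` reaches only a limit of this assay, > 50000 nM. Compound 3 `C=CCSc1nc2nc(C)cc(Nc3cc(-c4ccccc4)[nH]n3)n2n1` likewise reaches only a limit, > 50000 nM. Two of the three values thus sit at the limit of > 50000 nM in this assay, at which 2 of the 3 values shown sit. The measured steps leave the comparison largely open: an at least 1.3-fold higher number from compound 1 to compound 2 (0.14 log units; that floor lies within the scatter) and an at least 1.3-fold higher number from compound 1 to compound 3 (0.14 log units; that floor lies within the scatter), while a step that the two limits leave unreadable from compound 2 to compound 3. Each of these steps removes the 4-methylphenyl group altogether, putting cyclopropyl or vinyl in its place on the saturated chain carbon bound to sulfur.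

Compound 4 `COc1ccc(CSc2nc3nc(C)cc(Nc4cc(-c5ccccc5)[nH]n4)n3n2)cc1` keeps that ring and alters only its substituent: methoxy in place of methyl on an aromatic carbon. Among the compounds with values here, none of the measured steps changes a group on that ring, so they do not bear on this change, and no step beyond the scatter is expected in this assay in either direction. Compound 4 is therefore estimated to give 36000 nM, between 15000 nM and 80000 nM, in this assay. That estimate means a 1.0-fold lower number from compound 1 to compound 4 (0.00 log units; within the scatter), a step expected to stay within the scatter of repeated measurements.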

Compound 4, half-maximal inhibitory concentration: 28200 nM
Compound 4: middle estimate off by 1.3-fold (0.11 log units), on the high side; low and high end bracket the measured number.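

Going by these compounds alone, the result is the first look at a change on the ring itself, where the earlier steps removed the ring altogether. In this assay, the change on the aromatic carbon, para to a large group, gives a 1.3-fold lower number from compound 1 to compound 4 (0.11 log units; within the scatter), so methoxy in place of methyl leaves the number within the scatter. Compound 4 also provides a second outright number for a compound that keeps the ring, against which the smaller arms can be read, giving an at least 1.7-fold lower number from compound 3 to compound 4 (0.24 log units; that floor lies within the scatter) and an at least 1.7-fold lower number from compound 2 to compound 4 (0.24 log units; that floor lies within the scatter), but neither floor clears the scatter and compound 2 and compound 3 each remain at a limit of the assay: the limit of > 50000 nM in this assay, at which 2 of the 4 values shown sit.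

The compounds shown leave open whether another group at this place on the ring, such as chlorine, a hydroxyl or an amine, would carry the number beyond the scatter. They also leave open what a longer chain in place of the saturated chain carbon bound to a sulfur would do in this assay.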